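A few compounds are considered here, and "the series" means these few. Any claim that something is new, unique, unknown or untested is made for them only; others in the source may bear on it.

Measured so far:
compound 1 `CCCCC(N)c1cc(C(F)(F)F)ccc1N1CCN(C(=O)CCc2ccc(Cl)cc2Cl)CC1` — 190 nM
compound 2 `CCC(C)[C@H](N)c1cc(C(F)(F)F)ccc1N1CCN(C(=O)CCc2ccc(OC)cc2Cl)CC1` — 57 nM

In an assay on HEK293 cells for displacement of a labelled ligand from Melanocortin receptor 4 (Homo sapiens) (on this read-out lower numbers stand for stronger inhibition and higher numbers for weaker inhibition), compound 1 gives 190 nM, the higher of the two numbers available in the series. Compound 2 gives 57 nM in this assay, a lower number than that of compound 1 by a margin that lies beyond the usual scatter. Among the measured compounds shown here, the two compounds differ in more than one place, so no single step joins them and the comparison says nothing about what any one change does on its own.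

Compound 3 `CCC(C)[C@H](NCCN)c1cc(C(F)(F)F)ccc1N1CCN(C(=O)CCc2ccc(Cl)cc2Cl)CC1` has not yet been measured in this assay. Relative to compound 1 it carries 1-((2-aminoethyl)amino)-2-methylbutyl in place of 1-aminopentyl on an aromatic carbon. For the measured compounds named here, no measured pair shows this change, so neither its size nor its direction can be taken from the data. The expectation is a small step, a 1.6-fold lower number from compound 1 to compound 3 (0.20 log units; within the scatter), not clearly beyond what repeated measurements would scatter over, with a wide margin on either side. For compound 3 the estimated value in this assay is 120 nM, expected to fall between 30 nM and 500 nM.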

Compound 3, inhibition constant: 56 nM
Estimate against measurement, compound 3: 2.1-fold (0.33 log units) above; the measured number falls inside the stated range.
By their numbers in this assay, from the lowest: compounds 3 and 2 (each within the scatter of the next); then compound 1.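

Among the compounds shown here, compound 3 gives the first readable step at this position, on an aromatic carbon ortho to a large group and meta to a trifluoromethyl group: in this assay, 1-((2-aminoethyl)amino)-2-methylbutyl in place of 1-aminopentyl gives a 3.4-fold lower number from compound 1 to compound 3 (0.53 log units; beyond the scatter). The position therefore accepts a larger group with a second nitrogen and a defined stereocentre, with a number that falls rather than rises, so the 1-aminopentyl group of compound 1 is not the limit of what can stand here. Nothing available gives a reason for this step.

Going by these compounds, the branched chain and the 2-aminoethyl group on the nitrogen enter in one step, so their separate shares remain open, and compound 2, which has the branched chain with a free amine, differs from compound 3 in more than one place and does not divide them. Also open, on these data alone, is how this position responds when the terminal amine of the 2-aminoethyl group gives way to a hydroxyl or a carboxylic acid, or when a longer chain such as 3-aminopropyl takes its place.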